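A Pyridin-3-yl Swap on Compound 2

The compounds below may be only part of what the source reports. "The series", "measured", "known", "first", "only" and "open" are said of these compounds alone.

In a functional assay on K562 cells (Homo sapiens) for cytotoxicity, read by ELISA, with a stated time of 4 days (on this read-out lower numbers stand for stronger inhibition and higher numbers for weaker inhibition), compound 1 (`Cc1ccsc1-c1cc(-c2ccoc2)cc(-c2ccc(Cl)cc2)n1`) gives 19600 nM and compound 2 (`Cc1ccccc1-c1cc(-c2ccoc2)cc(-c2ccc(Cl)s2)n1`) gives 12300 nM. These two numbers lie within the usual scatter of each other, so compound 2 stands level with compound 1. The next structure, compound 3 (`Clc1ccc(-c2cc(-c3ccoc3)cc(-c3cccnc3)n2)s1`), carries pyridin-3-yl in place of 2-methylphenyl on an aromatic carbon, next to the ring nitrogen: pyridin-3-yl in place of 2-methylphenyl on an aromatic carbon. For the measured compounds named here, the measured compounds offer no step that isolates this change, so any expectation rests on thin evidence. No shift beyond the scatter is expected in this assay, and the estimated step is a 1.1-fold lower number from compound 2 to compound 3 (0.05 log units; within the scatter). With so little to go on, the range is kept wide. For compound 3 the expected value is 11000 nM, with an estimated range of 3500 nM to 35000 nM.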

Compound 3, half-maximal inhibitory concentration: 18700 nM
Compound 3: the middle estimate sits 1.7-fold (0.23 log units) below what was measured, within the range that was stated.
By their numbers in this assay, from the lowest: compounds 2, 3 and 1 (each within the scatter of the next).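

In this assay, placing pyridin-3-yl in place of 2-methylphenyl on an aromatic carbon next to the ring nitrogen gives a 1.5-fold higher number from compound 2 to compound 3 (0.18 log units; within the scatter). For the compounds shown here, this is the first single-place comparison, and it shows that this position accepts a six-membered aromatic ring with 1 hetero atom in place of one of carbon only, with the two numbers staying level in this assay. Nothing at hand bears on the reason for this result.

The compounds shown leave open whether an amine, a carboxylic acid or a longer chain at this position would move the number beyond the scatter. They also leave open how pyridin-4-yl would compare with pyridin-3-yl here, and whether replacing the furan-3-yl group with a morpholine would change the reading.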